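Moving a methoxy group around the phenyl ring

The source may hold more compounds than are shown below. What is called first, only, known or untested is meant among the compounds shown, and "the series" means these compounds.

Measured so far:
compound 1, `CCCN(CCC)c1cc(C)nc2c(-c3ccc(C#N)cc3)c(C)nn12`, 3.5 nM
compound 2, `CCCN(CCC)c1cc(C)nc2c(-c3ccccc3OC)c(C)nn12`, 15 nM

Compound 2 gives the highest of the two numbers in an assay on isolated protein for binding affinity to corticotropin-releasing factor receptor 1 (Homo sapiens); a lower number here means a stronger inhibitor, a higher number a weaker inhibitor; its nearest neighbour is compound 1, and the step of a 4.3-fold higher number from compound 1 to compound 2 (0.63 log units; beyond the scatter) lies beyond the scatter. The next compound, compound 3 with structure `CCCN(CCC)c1cc(C)nc2c(-c3cccc(OC)c3)c(C)nn12`, keeps every atom of compound 2 but joins them differently: 3-methoxyphenyl in place of 2-methoxyphenyl on an aromatic carbon. Among the compounds with values here, no measured step shows what happens when only the position of a methoxy group changes; the one step available, a 4.3-fold higher number from compound 1 to compound 2 (0.63 log units; beyond the scatter), swaps a 4-cyanophenyl for a 2-methoxyphenyl and so changes two things at once. On that basis no step beyond the scatter in this assay is expected in either direction, and the estimated step of a 1.2-fold higher number from compound 2 to compound 3 (0.08 log units; within the scatter) is small. For compound 3 the expected value in this assay is 18 nM, with a likely range from 5 nM to 70 nM.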

Compound 3, inhibition constant: 24 nM
The estimate for compound 3 lay 1.3-fold (0.12 log units) below the measured number; measured number inside the range.
By their numbers in this assay, from the lowest: compound 1; then compounds 2 and 3 (each within the scatter of the next).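

Swapping the 2-methoxyphenyl for the 3-methoxyphenyl on this aromatic carbon gives a 1.6-fold higher number from compound 2 to compound 3 (0.20 log units; within the scatter) in this assay and so, for this pair, where the methoxy group sits on the phenyl ring does not clearly separate the two compounds. Compared with the 4-cyanophenyl group, the 3-methoxyphenyl group gives a 6.9-fold higher number from compound 1 to compound 3 (0.84 log units; beyond the scatter) and so, like compound 2, compound 3 stands apart from compound 1 by more than the scatter. No measurement available here bears on why these numbers fall as they do.

As far as these compounds go, it remains open whether a 4-methoxyphenyl group would give a number close to those of compound 2 and compound 3 or close to that of compound 1. From the compounds shown here alone, it also remains open how a 3-cyanophenyl group, or an amine or a carboxylic acid on the phenyl ring, would compare.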